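This account rests on a few compounds, and the source may have more. Where it says the series, first, only, none or still open, it means among the compounds named here.

Measured compounds:
- compound 1, `FC(F)(F)c1cc(/N=N/Nc2ccc(Cl)c(C(F)(F)F)c2)ccc1Cl`: 58400 nM
- compound 2, `O=[N+]([O-])c1ccc(/N=N/Nc2ccc([N+](=O)[O-])cc2Br)c(Br)c1`: 940 nM
- compound 3, `CC(=O)N(/N=N/c1ccc([N+](=O)[O-])cc1Cl)c1ccc([N+](=O)[O-])cc1Cl`: 630 nM

Three compounds have been run in a functional assay on HeLa cells (Homo sapiens) for cytotoxicity, read by MTT assay, with a stated time of 72 h; on this read-out higher numbers stand for weaker inhibition and lower numbers for stronger inhibition. Compound 1 gives 58400 nM, compound 2 gives 940 nM and compound 3 gives 630 nM. Compound 3 has the lowest number of the three, but its gap to compound 2 lies within the scatter of repeated measurements, so the two cannot be ranked against each other; only its gap to compound 1 is beyond the scatter, and there compound 3 stands clearly at the lower number.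

Compound 4, `O=C(c1cccc(F)c1)N(/N=N/c1ccc([N+](=O)[O-])cc1Cl)c1ccc([N+](=O)[O-])cc1Cl`, has not yet been measured in this assay. It differs from compound 3 in one place: 3-fluorophenyl in place of methyl on a carbonyl carbon. Going by the values given here, no pair of measured compounds shows a step of this kind, so there is no measured step to lean on. With the rest of the molecule unchanged, the expected step from compound 3 to compound 4 is small, a 1.1-fold higher number from compound 3 to compound 4 (0.05 log units; within the scatter), with no direction beyond the scatter that can be supported. Compound 4 is therefore expected to give 700 nM in this assay, within a range from 250 nM to 2500 nM.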

Compound 4, half-maximal inhibitory concentration: 2500 nM
The estimate for compound 4 lay 3.6-fold (0.55 log units) below the measured number, and the stated range covers the measured number.
By their numbers in this assay, from the lowest: compounds 3 and 2 (each within the scatter of the next); then compound 4; then compound 1.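

At the carbonyl carbon whose other neighbour is the amide-type nitrogen, the number in this assay responds to what is attached: 3-fluorophenyl in place of methyl gives a 4.0-fold higher number from compound 3 to compound 4 (0.60 log units; beyond the scatter), a modest step toward weaker inhibition but one that lies beyond the scatter. Going by these compounds alone, this is the first step measured at this position, and it shows that the acetyl group cannot be exchanged for (3-fluorophenyl)carbonyl without a cost in this read-out, even though the change brings in a six-membered aromatic ring and alters neither the count of hydrogen-bond donors and acceptors nor the net charge. Nothing measured here accounts for the size or direction of this step.

A single change cannot separate the contribution of the ring from that of the fluorine on it, so a plain phenyl group would be needed to tell the two apart. As far as these compounds go, whether a longer chain such as propyl, or a group carrying an amine or a carboxylic acid, would move the number in the same direction remains open.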